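This account rests on a few compounds, and the source may have more. Where it says the series, first, only, none or still open, it means among the compounds named here.

Measured compounds:
compound 1 `COc1cc2nc(N3CCC4CCC(C3)N4Cc3ccccc3)nc(Nc3ccc(S(C)(=O)=O)cc3F)c2cc1OC` — 44.3%
compound 2 `COc1cc2nc(Nc3ccc(S(C)(=O)=O)cc3)nc(N3CCC4CCC(C3)N4C(=O)OC(C)(C)C)c2cc1OC` — 37.5%
compound 3 `COc1cc2nc(Nc3ccc(S(C)(=O)=O)cc3F)nc(OCC3CCN(C(=O)OC(C)(C)C)CC3)c2cc1OC` — 21.3%

In a functional assay on HEK293 cells for agonist activity at Glucose-dependent insulinotropic receptor (Homo sapiens), read by cAMP accumulation, with a stated time of 60 min (on this read-out higher numbers stand for larger maximal responses and lower numbers for smaller maximal responses), compound 1 gives 44.3%, the largest of the three numbers shown. Its nearest neighbour is compound 2, whose 37.5% lies within the usual scatter of it, so the two cannot be told apart; compound 3, with 21.3%, lies beyond the scatter and clearly below compound 1.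

Compound 4 `COc1cc2nc(N3CCC4CCC(C3)N4Cc3ccccc3)nc(Nc3ccc(S(C)(=O)=O)cc3)c2cc1OC` has not yet been measured. It differs from compound 1 in one place: hydrogen in place of fluoro on an aromatic carbon. Among the measured compounds shown here, no pair of measured compounds shows this change alone; compound 2 carries the same hydrogen on that ring but differs from compound 1 elsewhere as well, so its value speaks only loosely to the change.

With the change being the loss of a single fluorine, the step from compound 1 to compound 4 in this assay is expected to be small, most likely within the scatter, if anything slightly downward. Compound 4 is therefore estimated at 40%, in the range 26% to 54%, a step of a number 4.3 percentage points lower from compound 1 to compound 4 (within the scatter).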

Compound 4, largest response reached (Emax), in percent of the reference or control that the assay uses: 23.4%
Estimate against measurement, compound 4: 16.6 percentage points above; measured number outside the range, below it.
By their numbers in this assay, from the lowest: compounds 3 and 4 (each within the scatter of the next); then compounds 2 and 1 (each within the scatter of the next).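

In this assay, hydrogen in place of fluoro on this aromatic carbon gives a number 20.9 percentage points lower from compound 1 to compound 4 (beyond the scatter). This is the only one-place reading of the position among the compounds shown, and it shows that with the rest of compound 1 held fixed, the single fluorine ortho to a large group and meta to the methylsulfonyl group makes a difference to the maximal response larger than the usual scatter. No measurement shown here accounts for this drop.

The compounds shown leave open whether the response depends on fluoro itself or would also be kept by chloro, methyl or methoxy on the same carbon. Among the compounds shown here, they also leave open whether the step recurs when the benzyl group of compound 1 is replaced by another group, since no second pair shows this change.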